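The source may report more compounds than this note shows. Statements on the series, on what has been measured and on what is new or still open speak of the compounds shown alone.

Three compounds share one core and differ only in the groups carried by one phenyl ring. Compound 1 `Cc1ccc(C2=NN(C3=NC(c4ccccc4)CS3)C(c3cccc4ccccc34)C2)cc1C`, which carries two methyl groups on that ring, gives 1720 nM in a functional assay on HeLa cells (Homo sapiens) for inhibition, read by CCK-8 assay, with a stated time of 48 h; a higher number here means a weaker inhibitor, a lower number a stronger inhibitor. Compound 2 `Cc1ccc(C2=NN(C3=NC(c4ccccc4)CS3)C(c3cccc4ccccc34)C2)cc1` keeps a single methyl and gives 4290 nM in this assay. Compound 3 `Clc1ccc(C2=NN(C3=NC(c4ccccc4)CS3)C(c3cccc4ccccc34)C2)cc1` carries a chloro instead and gives 9940 nM in this assay, the highest number of the three. The steps between them are a 2.5-fold higher number from compound 1 to compound 2 (0.40 log units; beyond the scatter), a 2.3-fold higher number from compound 2 to compound 3 (0.36 log units; beyond the scatter) and a 5.8-fold higher number from compound 1 to compound 3 (0.76 log units; beyond the scatter), so each change moved the number upward by a modest amount.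

Compound 4 `Brc1ccc(C2=NN(C3=NC(c4ccccc4)CS3)C(c3cccc4ccccc34)C2)cc1` differs from compound 3 by bromo in place of chloro on an aromatic carbon. Within the data shown here, none of the measured steps exchanges one halogen for another; the closest is the step of a 2.3-fold higher number from compound 2 to compound 3 (0.36 log units; beyond the scatter), in which a methyl became a chloro. With no measured guidance on a chloro-to-bromo exchange, the expected step of a 1.0-fold higher number from compound 3 to compound 4 (0.00 log units; within the scatter) is small, not clearly beyond the scatter. Compound 4 is therefore estimated at 10000 nM in this assay, within a range of 4000 nM to 25000 nM.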

Compound 4, half-maximal inhibitory concentration: 6650 nM
Estimate against measurement, compound 4: 1.5-fold (0.18 log units) above; low and high end bracket the measured number.
By their numbers in this assay, from the lowest: compound 1; then compounds 2, 4 and 3 (each within the scatter of the next, the first and the last beyond it).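

In this assay, among these compounds, this is the first exchange of one halogen for another at this position, on an aromatic carbon para to a large group, and it gives a step that does not separate chloro from bromo (a 1.5-fold lower number from compound 3 to compound 4 (0.17 log units; within the scatter)). Bromo cannot be told apart from the single methyl here either (a 1.6-fold higher number from compound 2 to compound 4 (0.19 log units; within the scatter)), even though chloro could be (a 2.3-fold higher number from compound 2 to compound 3 (0.36 log units; beyond the scatter)), so compound 4 sits within the scatter of both compound 2 and compound 3. The 3,4-dimethylphenyl group of compound 1 remains clearly apart (a 3.9-fold higher number from compound 1 to compound 4 (0.59 log units; beyond the scatter)), and no supporting evidence bears on why these numbers fall as they do.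

The compounds shown leave open how an amine, a carboxylic acid or a methoxy group would read at this position. They also leave open how much changes elsewhere on the shared core would move the number.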